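Aryl swap on the ring amine nitrogen of compound 2

The source may hold more compounds than are shown below. What is called first, only, known or untested is meant among the compounds shown, and "the series" means these compounds.

Among the compounds with values here, compound 2 `O=C(Nc1ccccc1Br)N[C@@H]1CCN(c2ccccn2)C1` is one of two compounds measured so far in a functional assay for antagonist activity at transient receptor potential cation channel subfamily V member 1 (Rattus norvegicus), read by FLIPR; on this read-out higher numbers stand for higher potency (the scale is a negative logarithm) and lower numbers for lower potency. In this assay compound 2 gives < 6.6, which is a limit of the assay rather than a number. Compound 1 `O=C(Nc1ccccc1Br)N[C@@H]1CCN(c2ccc(Br)cn2)C1` gives 7.2. Within the data shown here, the only measured step, a number at least 0.60 log units lower from compound 1 to compound 2 (beyond the scatter), exchanges bromo for hydrogen on an aromatic carbon and ends at the limit of < 6.6 in this assay, at which 1 of the 2 values shown sits. Compound 3 `O=C(Nc1ccccc1Br)N[C@@H]1CCN(c2ccc(F)c(F)c2)C1` is not yet measured; it differs from compound 2 by 3,4-difluorophenyl in place of pyridin-2-yl on an amine nitrogen in a ring. Among the measured compounds shown here, no measured step covers this change, so its size and direction cannot be read from the data, and the starting point is uncertain because compound 2 stands at the limit of < 6.6 in this assay, at which 1 of the 2 values shown sits. Compound 3 is therefore estimated at 6.8, with a range from 6 to 7.6. This estimate corresponds to an expected step of a number at least 0.20 log units higher from compound 2 to compound 3 (that floor lies within the scatter), with a real chance that only a limit is reported.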

Compound 3, negative logarithm of the antagonist equilibrium constant: 8.1
Beside the measured number, compound 3's estimate is 1.30 log units below it; the measured number lies above the stated range.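

The aryl group on the ring amine nitrogen is a strong handle on potency in this assay: 3,4-difluorophenyl in place of pyridin-2-yl gives a number at least 1.50 log units higher from compound 2 to compound 3 (beyond the scatter). The same aryl group also outperforms the brominated pyridine, with 3,4-difluorophenyl in place of 5-bromopyridin-2-yl giving a number 0.90 log units higher from compound 1 to compound 3 (beyond the scatter), so the potency of compound 1 does not mark the ceiling at this position. The larger step gives only a floor and not a full size, because compound 2 is represented by a limit: the limit of < 6.6 in this assay, at which 1 of the 3 values shown sits.

Going by these compounds, this change replaces the ring type and adds both fluorines at once, so it remains open which of the two carries the gain, and a plain phenyl on this nitrogen would separate them. On these data alone, how chloro or methoxy on that phenyl would stand also remains open.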